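The compounds below may be only part of what the source reports. "The series", "measured", "known", "first", "only" and "open" are said of these compounds alone.

Of the compounds shown here, three built on one shared core have been tested in a functional assay on the whole organism (strain Wistar) for inhibition, with Rattus norvegicus as the target, read by paw edema, with stated times of 60 min and 4 h, at a dose of 100 mg/kg by the oral route; a higher number here means more inhibition at the dose given (going by the name of the read-out), a lower number less inhibition. Compound 1 `CNC(=O)CC1CCc2cc(OC)c(OC)cc21` gives 29.7% in this assay. Compound 2 `COc1cc2c(cc1OC)C(CC(=O)N(C)C)CC2` gives 35.9% in this assay. Compound 3 `COc1cc2c(cc1OC)C(CC(=O)N1CCNCC1)CC2` gives 40.6% in this assay. Compound 2 sits close to both of the others: the step of a number 6.2 percentage points higher from compound 1 to compound 2 (within the scatter) and the step of a number 4.7 percentage points higher from compound 2 to compound 3 (within the scatter) each stay within the scatter of repeated measurements. For the measured compounds named here, only the step of a number 10.9 percentage points higher from compound 1 to compound 3 (beyond the scatter) reaches beyond the scatter, and then only modestly.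

Compound 4 `COc1cc2c(cc1OC)C(CC(=O)N1CCOCC1)CC2` has not yet been measured in this assay. It differs from compound 2 in a single place:

morpholin-4-yl in place of dimethylamino on a carbonyl carbon

The measured step that bears most directly on this change is the one in which piperazin-1-yl took the place of dimethylamino on the same carbonyl carbon, a number 4.7 percentage points higher from compound 2 to compound 3 (within the scatter), which stayed within the scatter. Nothing among the three measured compounds points to a larger effect from exchanging the group on this carbonyl carbon. For compound 4 the expected step is therefore a number 2.1 percentage points higher from compound 2 to compound 4 (within the scatter), that is, none beyond the scatter. Compound 4 is accordingly estimated to give 38% in this assay, with a range from 28% to 48%.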

Compound 4, a percentage reported as inhibition, in the whole organism at one dose (the size of the read-out at that dose, not a potency): 13.3%
Compound 4: middle estimate off by 24.7 percentage points, on the high side; measured number outside the range, below it.
By their numbers in this assay, from the lowest: compound 4; then compounds 1, 2 and 3 (each within the scatter of the next, the first and the last beyond it).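

Exchanging dimethylamino for morpholin-4-yl on this carbonyl carbon gives a number 22.6 percentage points lower from compound 2 to compound 4 (beyond the scatter) in this assay, so the group at this position can matter far more than the first three compounds suggested. A ring here does not by itself go with a low number: compound 3 carries piperazin-1-yl at the same place, and morpholin-4-yl in its place gives a number 27.3 percentage points lower from compound 3 to compound 4 (beyond the scatter). The small methylamino group of compound 1 also stands apart from morpholin-4-yl, with a number 16.4 percentage points lower from compound 1 to compound 4 (beyond the scatter) for that exchange, and no measurement shown here accounts for the drop.

The compounds shown leave open whether the low number is tied to the ring oxygen of morpholin-4-yl, a question that piperidin-1-yl, a ring with carbon in place of that oxygen, would help to answer. They also leave open how 4-methylpiperazin-1-yl would compare with piperazin-1-yl, and whether the gap between these groups would persist at doses other than the single one used.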